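Ethoxycarbonyl in place of carboxymethoxy on the shared core

This account rests on a few compounds, and the source may have more. Where it says the series, first, only, none or still open, it means among the compounds named here.

Two compounds on the shared core have numbers in an assay on isolated protein (strain Sprague-Dawley) for inhibition of Amine oxidase [flavin-containing] A (Rattus norvegicus), read by spectrophotometry, with a stated time of 5 min, tested at 10 uM; on this read-out lower numbers stand for less inhibition and higher numbers for more inhibition at the one concentration tested (going by the name of the read-out). Compound 1 `CCOc1cc(=O)oc2cc(OCc3cccc(F)c3)ccc12` gives 25% in this assay. Compound 2 `O=C(O)COc1cc(=O)oc2cc(OCc3cccc(Cl)c3)ccc12` gives 0% in this assay, the lowest of the two numbers; compound 1 is its nearest neighbour and stands higher by a margin beyond the usual scatter. Among the compounds with values here, no pair of measured compounds differs in only one place, so no single measured step is available to guide the next change.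

Compound 3 `CCOC(=O)c1cc(=O)oc2cc(OCc3cccc(Cl)c3)ccc12` differs from compound 2 in one place: ethoxycarbonyl in place of carboxymethoxy on an aromatic carbon. Within the data shown here, with no measured step of this kind, the expectation rests on compound 2 at 0% and on compound 1 at 25% as the only other number on the core. The step of a number 18 percentage points higher from compound 2 to compound 3 (beyond the scatter) is expected to be a rise of moderate size, close to the edge of the scatter rather than clearly beyond it. Compound 3 is therefore estimated at 18%, with a range from 0% to 42%.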

Compound 3, a percentage reported as inhibition, at one concentration (the size of the read-out at that concentration, not a potency): 4.4%
Compound 3: the middle estimate sits 13.6 percentage points above what was measured; the range from low to high includes it.
By their numbers in this assay, from the lowest: compounds 2 and 3 (each within the scatter of the next); then compound 1.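

In this assay, within the data shown here, ethoxycarbonyl in place of carboxymethoxy on an aromatic carbon, opposite the ring oxygen, gives a number 4.4 percentage points higher from compound 2 to compound 3 (within the scatter) and is the first single-place step read at this position. The two groups cannot be told apart on this read-out at the one concentration tested, even though the hydrogen-bond donor counted on carboxymethoxy is absent from ethoxycarbonyl. No measurement at hand speaks to why these two groups read alike.

As far as these compounds go, whether an amine, an amide or a longer chain in place of ethoxycarbonyl at this position would read differently remains open. Compound 1, at 25% in this assay, differs from compound 2 and compound 3 in more than one place, so what separates it from them also remains unresolved.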